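This account rests on a few compounds, and the source may have more. Where it says the series, first, only, none or still open, it means among the compounds named here.

Working notes on the pyrazole chalcone series.

Three compounds have numbers in a functional assay on A498 cells (Homo sapiens) for cytotoxicity, read by sulforhodamine B assay, with a stated time of 48 h, tested at 0.01 uM; a higher number here means a weaker effect of the compound at the concentration tested, a lower number a stronger effect. Compound 1 `COc1cc(-c2cc(/C=C/C(=O)c3ccc(Cl)c(Cl)c3)[nH]n2)cc(OC)c1OC` gives 84% in this assay, the lowest of the three numbers. Compound 3 `COc1ccc(-c2cc(/C=C/C(=O)c3ccc(N)cc3)[nH]n2)cc1` gives 88%, a number close to that of compound 1 and within the scatter of it. Compound 2 `COc1ccc(-c2cc(/C=C/C(=O)c3cc(OC)c(OC)c(OC)c3)[nH]n2)cc1OC`, which carries methoxy groups on the aryl at the carbonyl carbon, gives 99%, a number beyond the scatter above compound 1.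

Compound 4 `COc1ccc(C(=O)/C=C/c2cc(-c3cc(OC)c(OC)c(OC)c3)n[nH]2)cc1OC` has not yet been measured. It differs from compound 1 in one place: 3,4-dimethoxyphenyl in place of 3,4-dichlorophenyl on a carbonyl carbon. Among the compounds with values here, no step between two measured compounds is known for this exchange, so the expectation rests on the spread of the three numbers. Because compound 2 gives 99% with methoxy groups on the aryl at the carbonyl carbon, a small step upward in this assay is expected, of a size near the edge of the scatter rather than beyond it. The step from compound 1 to compound 4 is estimated at a number 8 percentage points higher from compound 1 to compound 4 (within the scatter). For compound 4 the value in this assay is estimated at 92%, with a range from 80% to 104%.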

Compound 4, a percentage reported as activity, at one concentration (the size of the read-out at that concentration, not a potency): 97%
For compound 4 the middle estimate is 5 percentage points below the measured one; measured number inside the range.
By their numbers in this assay, from the lowest: compounds 1, 3, 4 and 2 (each within the scatter of the next, the first and the last beyond it).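

In this assay, 3,4-dimethoxyphenyl in place of 3,4-dichlorophenyl on a carbonyl carbon gives a number 13 percentage points higher from compound 1 to compound 4 (beyond the scatter). Within the data shown here, this is the only step with the rest of the structure held fixed, so the group at this position alone is enough to weaken the effect at the concentration tested, which the earlier comparisons, each differing in more than one place, could not show. No measurement shown here accounts for the size of this step.

From the compounds shown here alone, whether a single chlorine, a trifluoromethyl group or a carboxylic acid in this place would keep the number of compound 1 remains open. Also open, going by these compounds, is whether the same exchange gives a step of this size when the aryl group at the other end of the core differs.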